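Amine substituent series on the shared core: toward compound 4

A few compounds are considered here, and "the series" means these few. Any claim that something is new, unique, unknown or untested is made for them only; others in the source may bear on it.

Compound 3 `COc1cc(Oc2cccc(Nc3ccccc3)c2)cc(OC)c1CNC1CC1` carries a cyclopropyl on the amine nitrogen; in a functional assay on HCT-15 cells (Homo sapiens) for inhibition, read by MTT assay, with a stated time of 72 h (on this read-out higher numbers stand for weaker inhibition and lower numbers for stronger inhibition), compound 3 gives 6140 nM. Among the two numbers shown, compound 3 stands at the highest; compound 1 `COc1ccc(CCCNCc2c(OC)cc(Oc3cccc(Nc4ccccc4)c3)cc2OC)cc1`, with the 3-(4-methoxyphenyl)propyl on the same nitrogen, gives 730 nM in this assay, and the step of an 8.4-fold higher number from compound 1 to compound 3 (0.92 log units; beyond the scatter). Compound 2 `COc1cc(Oc2cccc(Nc3ccccc3)c2)cc(OC)c1CNC(C)C`, with isopropyl there, reaches only the limit > 20000 nM in this assay. The step of an at least 3.2-fold lower number from compound 2 to compound 3 (0.51 log units; beyond the scatter) is read against (the limit of > 20000 nM in this assay, at which 1 of the 3 values shown sits).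

Compound 4 `COc1cc(Oc2cccc(Nc3ccccc3)c2)cc(OC)c1CNCc1ccc(O)cc1` is not yet measured. It differs from compound 3 in one place: 4-hydroxybenzyl in place of cyclopropyl on an amine nitrogen. Among the measured compounds shown here, the change moves the nitrogen substituent back toward an arylalkyl group of the kind seen in compound 1, so the measured step bearing on it is the one from compound 1 to compound 3, which ran the other way and was modest; the step from compound 2 to compound 3 shows that the small alkyl substituents sit at the weak end. A lower number than compound 3 is therefore expected, of modest size, though the benzyl is shorter than the propyl chain of compound 1 and carries a hydroxy rather than a methoxy. The estimated step is a 4.1-fold lower number from compound 3 to compound 4 (0.61 log units; beyond the scatter). For compound 4 in this assay the estimate is 1500 nM, with a range from 400 nM to 6000 nM.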

Compound 4, half-maximal inhibitory concentration: 3430 nM
Beside the measured number, compound 4's estimate is 2.3-fold (0.36 log units) below it; measured number inside the range.
By their numbers in this assay, from the lowest: compound 1; then compounds 4 and 3 (each within the scatter of the next). At a limit, above all of these: compound 2.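

Placing 4-hydroxybenzyl on the amine nitrogen in place of cyclopropyl gives no separation beyond the scatter in this assay (a 1.8-fold lower number from compound 3 to compound 4 (0.25 log units; within the scatter)), so an aromatic ring on that nitrogen does not by itself reach the level of compound 1. The gap that remains (a 4.7-fold higher number from compound 1 to compound 4 (0.67 log units; beyond the scatter)) shows that the 3-(4-methoxyphenyl)propyl of compound 1 and the 4-hydroxybenzyl of compound 4 are not interchangeable here, although both are arylalkyl groups, which the small alkyl substituents could not show. The value of compound 2 is a limit, so the step from the isopropyl (an at least 5.8-fold lower number from compound 2 to compound 4 (0.76 log units; beyond the scatter)) gives only a minimum size and sets the 4-hydroxybenzyl apart from that group alone: the limit of > 20000 nM in this assay, at which 1 of the 4 values shown sits.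

Chain length and the hydroxy-to-methoxy swap change together between compound 4 and compound 1, so the compounds shown do not tell which of the two carries the gap. A 4-methoxybenzyl or a 3-(4-hydroxyphenyl)propyl on the same nitrogen would pull these two apart, and a 2-phenylethyl would test the intermediate chain.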